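The source may report more compounds than this note shows. Statements on the series, on what has been measured and on what is new or still open speak of the compounds shown alone.

Of the compounds shown here, three have been read in a physicochemical assay for solubility, read by HPLC; on this read-out higher numbers stand for higher solubility and lower numbers for lower solubility. Compound 1 `Cc1ccc([C@H](C(=O)N(C)C)N2C(=O)[C@@H](C3Cc4ccccc4C3)NC(=O)[C@H]2CC(C)C)cn1` gives > 236 ug/mL, which is a limit of the assay and not a number. Compound 3 `Cc1ccc([C@H](C(=O)N2CCOCC2)N2C(=O)[C@@H](C3Cc4ccccc4C3)NC(=O)[C@H]2CC2CC2)cn1` gives > 258 ug/mL, which is also a limit. Compound 2 `Cc1ccc([C@H](C(=O)N2CCCC2)N2C(=O)[C@@H](C3Cc4ccccc4C3)NC(=O)[C@H]2CC(C)C)cn1` gives a number, 241 ug/mL. Compound 1 therefore has no exact place on this scale.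

Compound 4 `CC(C)C[C@@H]1C(=O)N[C@H](C2Cc3ccccc3C2)C(=O)N1[C@@H](C(=O)N(C)C)c1ccc(O)nc1` differs from compound 1 at one place: hydroxy in place of methyl on an aromatic carbon. In words, hydroxy stands in place of methyl on an aromatic carbon, turning 6-methylpyridin-3-yl into 6-hydroxypyridin-3-yl. Within the data shown here, the only measured step, a step that the limit leaves unreadable from compound 1 to compound 2, lies elsewhere in the molecule and its size cannot be read, so no measured step bears on this change. With nothing to indicate a direction, the expectation leans on compound 2 at 241 ug/mL, and no change beyond the usual scatter is expected. The estimated step is a step that the limit leaves unreadable from compound 1 to compound 4. For compound 4 the expected value is 240 ug/mL, within an estimated range of 110 ug/mL to 320 ug/mL.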

Compound 4, solubility: > 240 ug/mL
Compound 4: only a limit was reported (the forecaster's own chance of this, stated with the estimate: 50%); the middle value sits exactly at the limit.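

In this assay compound 4 gives > 240 ug/mL, which is a limit and not a number. Among these compounds, compound 1 also stands at a limit, so no step between compound 1 and compound 4 can be read. From the compounds shown here alone, whether hydroxy in place of methyl shifts this read-out at all, and in which direction, stays open.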